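Moving one pyridine nitrogen in compound 2

This account rests on a few compounds, and the source may have more. Where it says the series, first, only, none or still open, it means among the compounds named here.

compound 1 `O=C1/C(=C/c2cccnc2)CNC/C1=C\c1ccccc1F`: 8890 nM
compound 2 `Cc1ccc(S(=O)(=O)N2C/C(=C\c3cccnc3)C(=O)/C(=C/c3ccccc3F)C2)cc1`: 9700 nM
compound 3 `O=C1/C(=C/c2cccnc2)CN(S(=O)(=O)c2ccc([N+](=O)[O-])cc2)C/C1=C\c1ccccc1F`: 5600 nM

All three values come from a functional assay on QGY-7703 cells (Homo sapiens) for cytotoxicity, read by MTT assay, with a stated time of 24 h; on this read-out lower numbers stand for stronger inhibition and higher numbers for weaker inhibition. Compound 2, at 9700 nM, has the highest number of the three, but it lies within the scatter of both others, so the three cannot truly be ranked.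

The next compound is compound 4 `Cc1ccc(S(=O)(=O)N2C/C(=C\c3ccncc3)C(=O)/C(=C/c3ccccc3F)C2)cc1`, and the change from compound 2 is pyridin-4-yl in place of pyridin-3-yl on a double-bonded chain carbon bound to a double-bonded ring carbon. For the measured compounds named here, no measured step alters this group, so the evidence is only indirect. Both measured steps were made elsewhere on the molecule and stayed within the scatter: a 1.1-fold higher number from compound 1 to compound 2 (0.04 log units; within the scatter), then a 1.7-fold lower number from compound 2 to compound 3 (0.24 log units; within the scatter). These small steps suggest a series that responds little to change, although they say nothing directly about the pyridine. In this assay, the expected 1.2-fold lower number from compound 2 to compound 4 (0.08 log units; within the scatter) is therefore no shift beyond the scatter, with no direction favoured. The estimated value for compound 4 is 8000 nM, with an expected range from 3800 nM to 17000 nM.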

Compound 4, half-maximal inhibitory concentration: > 20000 nM
Compound 4 ended at the assay's limit; the forecaster's own chance of this, stated with the estimate: 5%; at least 2.5-fold (0.39 log units) between middle value and limit.
By their numbers in this assay, from the lowest: compounds 3, 1 and 2 (each within the scatter of the next). At a limit, above all of these: compound 4.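

Replacing pyridin-3-yl with pyridin-4-yl on a double-bonded chain carbon bound to a double-bonded ring carbon gives an at least 2.0-fold higher number from compound 2 to compound 4 (0.31 log units; beyond the scatter) in this assay, the only step shown that lies beyond the scatter. The two groups have the same atoms and the same counts of donors and acceptors, so this series does respond at this position to a change in how those atoms are joined, although the changes made elsewhere stayed within the scatter. Compound 4 reads > 20000 nM, which is a limit of the assay and not a number, so the full size of the step stays unknown: the limit of > 20000 nM in this assay, at which 1 of the 4 values shown sits.

Going by these compounds, whether pyridin-2-yl or a plain phenyl at this position would behave like pyridin-3-yl or pyridin-4-yl remains open. The compounds shown also leave open whether the same swap would have a similar effect with the nitrophenylsulfonyl group of compound 3 or the free ring amine of compound 1.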